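This account rests on a few compounds, and the source may have more. Where it says the series, first, only, none or still open, it means among the compounds named here.

Compound 3 `Cc1cccc(NC(=O)c2ccc3cccc(O)c3n2)c1` shares its core with compound 1 `COc1ccccc1NC(=O)c1ccc2cccc(O)c2n1` and compound 2 `Cc1ccccc1NC(=O)c1ccc2cccc(O)c2n1`, three amides that differ only in the ring on the amide nitrogen. In an ADME assay on THP-1 cells (Homo sapiens) for cytotoxicity, read by WST assay, with a stated time of 24 h (on this read-out lower numbers stand for stronger inhibition and higher numbers for weaker inhibition), compound 3 gives only a limit of the assay, > 30000 nM. Compound 1 likewise gives only a limit, > 30000 nM. Compound 2 also gives only a limit, > 30000 nM. The step that the two limits leave unreadable from compound 1 to compound 2 and the step that the two limits leave unreadable from compound 2 to compound 3 both rest on (the limit of > 30000 nM in this assay, at which 3 of the 3 values shown sit). Compound 4 `O=C(Nc1ccc(F)cc1)c1ccc2cccc(O)c2n1` differs from compound 3 by 4-fluorophenyl in place of 3-methylphenyl on an amide-type nitrogen. Neither measured step gives a readable size for such a swap, so no step beyond the scatter in this assay can be predicted. Compound 4 is therefore expected to give 50000 nM, with a range from 20000 nM to 200000 nM. The expected step, a step that the limit leaves unreadable from compound 3 to compound 4, is accordingly small.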

Compound 4, half-maximal inhibitory concentration: > 30000 nM
Compound 4: a limit, no number; the forecaster's own chance of this, stated with the estimate: 85%; the middle value is on the limit's open side.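

Compound 4 also gives only a limit, so the steps to it from compound 2 and compound 3 cannot be read: the limit of > 30000 nM in this assay, at which 4 of the 4 values shown sit. The compounds shown leave open whether the ring on the amide nitrogen changes the result in this assay at all.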